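This account rests on a few compounds, and the source may have more. Where it says the series, first, only, none or still open, it means among the compounds named here.

Measured so far:
compound 1, `NS(=O)(=O)c1ccc(N2N=C(c3ccccc3)CC2c2ccccc2Cl)cc1`: 26000 nM
compound 2, `NS(=O)(=O)c1ccc(N2N=C(c3ccc(Oc4ccccc4)cc3)CC2c2ccccc2Cl)cc1`: 29000 nM

Both were read in an ADME assay on Vero 76 cells (Chlorocebus sabaeus) for cytotoxicity, read by MTT assay, with a stated time of 96 h; a lower number here means that less compound is tolerated, a higher number that more compound is tolerated. Compound 2 gives the higher of the two numbers, yet the gap to compound 1 is small: a 1.1-fold higher number from compound 1 to compound 2 (0.05 log units; within the scatter). The two compounds therefore show the same tolerance within the scatter, and no ranking between them can be drawn.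

Compound 3, `NS(=O)(=O)c1ccc(N2N=C(c3ccc(Oc4ccccc4)cc3)CC2c2ccc(Cl)cc2)cc1`, has not yet been tested. It differs from compound 2 in one place: 4-chlorophenyl in place of 2-chlorophenyl on a saturated ring carbon. The two compounds are built from the same atoms, joined differently, so nothing is added or removed.

For the measured compounds named here, only one measured step exists, the one from compound 1 to compound 2, and it concerns a phenoxy group on a different part of the molecule, not the chlorophenyl on the saturated ring carbon; it stayed within the scatter. Going by the values given here, no measured step speaks to the change at hand. With so little to go on, the expected step of no change at the digits printed from compound 2 to compound 3 (within the scatter) is none beyond the scatter. The estimate for compound 3 in this assay is 29000 nM, with a range from 12000 nM to 65000 nM.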

Compound 3, half-maximal cytotoxic concentration: 88000 nM
For compound 3 the middle estimate is 3.0-fold (0.48 log units) below the measured one; measured number above the stated range.
By their numbers in this assay, from the lowest: compounds 1 and 2 (each within the scatter of the next); then compound 3.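

In this assay, for the compounds shown here, putting 4-chlorophenyl in place of 2-chlorophenyl on the saturated ring carbon gives a 3.0-fold higher number from compound 2 to compound 3 (0.48 log units; beyond the scatter), the only step in this short series that lies beyond the scatter. Going by these compounds alone, the earlier step, which added phenoxy on a different part of the molecule, showed no such separation, so this saturated ring carbon is the first place where a single change moves the number, and the move is modest. Nothing is added or removed, and the two compounds differ only in how the same atoms are joined. Nothing available here explains why this rearrangement of the chlorophenyl group goes with a higher number.

From the compounds shown here alone, it remains open whether the same exchange would give a similar step on the core of compound 1, which carries hydrogen in place of the phenoxy group. It is also open how a plain phenyl, a 3-chlorophenyl or a 4-methoxyphenyl group on that saturated ring carbon would compare with the two chlorophenyl groups shown here.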